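This account rests on a few compounds, and the source may have more. Where it says the series, first, only, none or still open, it means among the compounds named here.

Series of glycosylated terpenoid esters and amides assayed in a toxicity assay on NCI-H460 cells (Homo sapiens) for cytotoxicity, read by MTT assay, with a stated time of 48 h; on this read-out higher numbers stand for weaker inhibition and lower numbers for stronger inhibition. Compound 1 `COc1cc(C)c(C(=O)N[C@@H]2[C@@H](C)O[C@@H](O[C@H]3CC[C@H](C)[C@@H]4[C@@H]3C=C(C)[C@H]3/C(C)=C/CC/C(C)=C/[C@@H]5C=C(C(=O)O)[C@H](C)C[C@]56OC(=O)C(=C6O)C(=O)[C@@]43C)[C@H](O)[C@]2(C)O)c(O)c1` reaches only the limit of this assay, > 30000 nM. Compound 2 `COc1cc(C)c(C(=O)N[C@@H]2[C@@H](C)O[C@@H](O[C@H]3CC[C@H](C)[C@@H]4[C@@H]3C=C(C)[C@H]3/C(C)=C/CC/C(C)=C/[C@]5(C)C=C(C(=O)O)[C@H](C)C[C@]56OC(=O)C(=C6O)C(=O)[C@@]43C)[C@H](O)[C@]2(C)O)c(O)c1` likewise gives a limit, > 30000 nM. Compound 3 `COc1cc(C)c(C(=O)O[C@H]2[C@@H](O)[C@@H](O)[C@H](O[C@H]3CC[C@H](C)[C@@H]4[C@@H]3C=C(C)[C@H]3/C(C)=C/CC/C(C)=C/[C@]5(C)C=C(C(=O)O)[C@H](C)C[C@]56OC(=O)C(=C6O)C(=O)[C@@]43C)O[C@@H]2C)c(O)c1`, the ester analogue, also stands at a limit, > 30000 nM, so no number places it against the others; all three values sit at the limit of > 30000 nM in this assay, at which 3 of the 3 values shown sit.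

Compound 4 `COc1cc(C)c(C(=O)O[C@H]2[C@@H](O)[C@@H](O)[C@H](O[C@H]3CC[C@H](C)[C@@H]4[C@@H]3C=C(C)[C@H]3/C(C)=C/CC/C(C)=C/[C@]5(C)C=C(C(=O)O)[C@H](C)C[C@]56OC(=O)C(=C6O)C(=O)[C@@]43C)O[C@@H]2C)c(OC)c1` is the next member. Its difference from compound 3: methyl in place of hydrogen on an oxygen on an aromatic ring. Going by the values given here, no measured step of this kind exists. The expected step from compound 3 to compound 4, a number no higher from compound 3 to compound 4 (the limit leaves the size open), is none beyond the scatter, since the series shows no movement off the limit. Compound 4 is therefore expected near 30000 nM, within 12000 nM to 100000 nM, most likely reported again only as a limit.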

Compound 4, half-maximal inhibitory concentration: > 30000 nM
Compound 4: only a limit was reported (the forecaster's own chance of this, stated with the estimate: 85%); the middle value sits exactly at the limit.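

Compound 3 and compound 4 both stand only at a limit in this assay, so the hydroxy to methoxy change yields no readable step: the limit of > 30000 nM in this assay, at which 4 of the 4 values shown sit.

The compounds shown leave open whether any structure in this series gives a numerical value in this assay.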